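Trifluoromethoxy in place of fluoro at the assay limit

This account rests on a few compounds, and the source may have more. Where it says the series, first, only, none or still open, it means among the compounds named here.

In a functional assay on T47D cells (Homo sapiens) for cytotoxicity, read by MTT assay, with a stated time of 2 days (a lower number here means a stronger inhibitor, a higher number a weaker inhibitor), compound 1 (`Cc1cccc(-c2nc3ccc(C)cc3c(=O)[nH]2)c1`) gives > 50000 nM as a limit of the assay.
Compound 2 (`Cc1ccc2nc(-c3cccc(C(F)(F)F)c3)[nH]c(=O)c2c1`) gives > 50000 nM as a limit too.
Compound 3 (`Cc1ccc2nc(-c3cccc(F)c3)[nH]c(=O)c2c1`) gives > 50000 nM as a limit as well, so it has no number of its own (the limit of > 50000 nM in this assay, at which 3 of the 3 values shown sit).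

Compound 4 (`Cc1ccc2nc(-c3cccc(OC(F)(F)F)c3)[nH]c(=O)c2c1`) differs from compound 3 by trifluoromethoxy in place of fluoro on an aromatic carbon, meta to a large group (trifluoromethoxy in place of fluoro on an aromatic carbon).

The closest measured change is a step that the two limits leave unreadable from compound 2 to compound 3 and the other two are a step that the two limits leave unreadable from compound 1 to compound 3 and a step that the two limits leave unreadable from compound 1 to compound 2 in this assay so none gives a size to carry over.

No direction is expected, and the expected step is a number no higher from compound 3 to compound 4 (the limit leaves the size open) within the scatter.
Compound 4 is estimated at 50000 nM with an expected range from 20000 nM to 100000 nM and most likely only a limit again.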

Compound 4, half-maximal inhibitory concentration: > 50000 nM
Compound 4: only a limit was reported; the forecaster's own chance of this, stated with the estimate: 80%; the middle value sits exactly at the limit.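

Compound 4 gives no readable step against compound 1, compound 2 or compound 3: the limit of > 50000 nM in this assay, at which 4 of the 4 values shown sit.

The compounds shown leave open whether any of these four aromatic substituents differs from the others in this assay.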